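The source may report more compounds than this note shows. Statements on the series, on what has been measured and on what is new or still open speak of the compounds shown alone.

Of the compounds shown here, three have so far been measured in an assay on HepG2 cells for agonist activity at nuclear receptor subfamily 1 group I member 3 (Homo sapiens), read by a luciferase reporter, with a stated time of 23 h; on this read-out higher numbers stand for an effect only at larger amounts of compound and lower numbers for an effect already at smaller amounts. Compound 1 `Clc1ccc(CO/N=C/c2c(-c3ccc4ccccc4c3)nc3occn23)cc1Cl` gives 370 nM, compound 3 `Clc1ccc(-c2nc3occn3c2/C=N/OCc2ccc(Cl)c(Cl)c2)cc1` gives 410 nM, and the step of a 1.1-fold higher number from compound 1 to compound 3 (0.04 log units; within the scatter) lies within the scatter. Compound 2 `N#Cc1ccc(-c2nc3sccn3c2/C=N/OCc2ccc(Cl)c(Cl)c2)cc1` gives 3400 nM, the highest of the three numbers, set well apart from compound 3 and compound 1. Compound 4 `CC(C)(C)c1ccc(-c2nc3sccn3c2/C=N/OCc2ccc(Cl)c(Cl)c2)cc1` differs from compound 2 in one place: tert-butyl in place of cyano on an aromatic carbon. For the measured compounds named here, no measured step covers this change; compound 2 and compound 3 differ both in the group on the phenyl ring and in the shared core, so their values are only a loose guide. A lower number is nevertheless expected for compound 4, as the step of a 3.4-fold lower number from compound 2 to compound 4 (0.53 log units; beyond the scatter). Compound 4 is estimated at 1000 nM, within 250 nM to 4000 nM.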

Compound 4, half-maximal effective concentration: 2400 nM
The estimate for compound 4 lay 2.4-fold (0.38 log units) below the measured number; low and high end bracket the measured number.
By their numbers in this assay, from the lowest: compounds 1 and 3 (each within the scatter of the next); then compounds 4 and 2 (each within the scatter of the next).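

In this assay, tert-butyl in place of cyano on the aromatic carbon gives a 1.4-fold lower number from compound 2 to compound 4 (0.15 log units; within the scatter). At this position, then, two groups that differ in heavy atoms and hydrogen-bond acceptors give numbers that cannot be told apart. Nothing available explains this result.

As far as these compounds go, whether an amine or a carboxylic acid at this position would move the number beyond the scatter remains open. So does whether tert-butyl and cyano would also match on the core of compound 3.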